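A Larger Saturated Group on the Ether Chain

The source may report more compounds than this note shows. Statements on the series, on what has been measured and on what is new or still open speak of the compounds shown alone.

Compound 1 `Cn1c(=O)c2[nH]c(Cc3ccc(OCCCn4ccnc4)cc3)nc2n(C)c1=O`: in an assay on CHO cells for binding affinity to adenosine receptor A2b (Homo sapiens), with a stated time of 20 min (on this read-out higher numbers stand for weaker inhibition and lower numbers for stronger inhibition), compound 1 gives > 10 nM, which is a limit of the assay and not a number.
Compound 2 `Cn1c(=O)c2[nH]c(-c3ccc(OCCCCl)cc3)nc2n(C)c1=O`: compound 2 gives > 10 nM, again a limit.
Compound 3 `Cn1c(=O)c2[nH]c(-c3ccc(OCCC4CCNCC4)cc3)nc2n(C)c1=O`: compound 3 gives 2.9 nM.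

Compound 1 therefore stands at the limit of > 10 nM in this assay, at which 2 of the 3 values shown sit, so only a lower bound is known for it, and its distance to compound 3 cannot be stated. Compound 4 `Cn1c(=O)c2[nH]c(Cc3ccc(OCCCN4CCC5(CC4)OCCO5)cc3)nc2n(C)c1=O` keeps the core of compound 1 and changes only the end of the chain: a group of 10 heavy atoms (7 carbon, 1 nitrogen, 2 oxygen; one five-membered non-aromatic ring with 2 hetero atoms, one six-membered non-aromatic ring with 1 hetero atom) in place of a group of 5 heavy atoms (3 carbon, 2 nitrogen; one five-membered aromatic ring with 2 hetero atoms), on a saturated chain carbon, three bonds along the chain from an oxygen on an aromatic ring.

Among the measured compounds shown here, the one measured step that bears on this change is an at least 3.4-fold lower number from compound 2 to compound 3 (0.53 log units; beyond the scatter), where a saturated nitrogen-containing ring entering the chain moved the value from a limit to a number. The change from compound 1 to compound 4 is not the same: the entering group is larger, the group that leaves is aromatic, and the site sits one bond further along the chain. Still, the direction of that step suggests a lower number for compound 4, beyond the scatter, though a result that remains at the limit cannot be excluded.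

Compound 4 is expected to give 5 nM, within 1.5 nM to 20 nM. This estimate implies an at least 2.0-fold lower number from compound 1 to compound 4 (0.30 log units; that floor lies within the scatter).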

Compound 4, inhibition constant: > 10 nM
Compound 4 gave a limit, no number; the forecaster's own chance of this, stated with the estimate: 35%; at least 2.0-fold (0.30 log units) between middle value and limit.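

Among the compounds shown here, compound 1 and compound 4 each give a limit and not a number in this assay, so no step between them can be read. That limit is a common result in this set: the limit of > 10 nM in this assay, at which 3 of the 4 values shown sit. The compounds shown leave open how the 1H-imidazol-1-yl group and the larger group entering in compound 4 compare in this assay.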